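Two inactive chalcones and a bromophenol successor

The source may hold more compounds than are shown below. What is called first, only, known or untested is meant among the compounds shown, and "the series" means these compounds.

Measured so far:
compound 1 `COc1ccc(/C=C/C(=O)c2ccc(OC)c3c2OC(C)(C)C=C3)cn1`: > 10000 nM
compound 2 `COc1ccc(C(=O)/C=C/c2cccc3ccccc23)c2c1C=CC(C)(C)O2`: > 10000 nM

In a functional assay on SW-620 cells (Homo sapiens) for antiproliferative activity, read by MTT assay, with a stated time of 24 h (a lower number here means a stronger inhibitor, a higher number a weaker inhibitor), compound 1 reaches only the limit of > 10000 nM and gives no number. Compound 2 likewise sits at the limit of > 10000 nM in this assay. Compound 1 thus stands where both shown values sit, at the limit of > 10000 nM in this assay, at which 2 of the 2 values shown sit. Compound 3 `COc1ccc(C(=O)/C=C/c2ccc(O)c(Br)c2)c2c1C=CC(C)(C)O2` differs from compound 1 by 3-bromo-4-hydroxyphenyl in place of 6-methoxypyridin-3-yl on a double-bonded chain carbon bound to a double-bonded chain carbon. Among the measured compounds shown here, no measured step accompanies this change, so no shift beyond the usual scatter is expected from it in this assay. Compound 3 is estimated at 15000 nM, between 4000 nM and 60000 nM, a step that the limit leaves unreadable from compound 1 to compound 3 that is expected to be none beyond the scatter.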

Compound 3, half-maximal inhibitory concentration: > 10000 nM
Compound 3 ended at the assay's limit; the forecaster's own chance of this, stated with the estimate: 70%; the middle value lies beyond the limit too.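

Among the compounds shown here, with compound 1 and compound 3 both resting on a limit in this assay, no step between them can be read. The compounds shown leave open whether 3-bromo-4-hydroxyphenyl and 6-methoxypyridin-3-yl differ in effect at all.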